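Methyl in place of hydrogen: compound 2 to compound 4

A few compounds are considered here, and "the series" means these few. Any claim that something is new, unique, unknown or untested is made for them only; others in the source may bear on it.

Three members of this series have numbers in an ADME assay on microsomes from liver (Homo sapiens) for metabolic stability; a higher number here means that the compound lasts longer, a lower number that the compound disappears faster. Compound 1 `CC(=O)N1CC=C(c2ccn3c(-c4ccc(NC(=O)c5ccc([N+](=O)[O-])o5)cc4)cnc3c2)CC1` gives 0.225 h in this assay. Compound 2 `O=C(Nc1ccc(-c2cnc3ccccn23)cc1)c1ccc([N+](=O)[O-])o1` gives 0.412 h in this assay, and compound 3 `COc1ccn2c(-c3ccc(NC(=O)c4ccc([N+](=O)[O-])o4)cc3)cnc2c1` gives 0.472 h in this assay. Compound 2 stands second highest of the three; its nearest neighbour is compound 3, with a 1.1-fold higher number from compound 2 to compound 3 (0.06 log units; within the scatter), and the furthest is compound 1, with a 1.8-fold higher number from compound 1 to compound 2 (0.26 log units; within the scatter). Neither gap leaves the scatter, so no order among the three is claimed.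

Compound 4 `Cc1cc(-c2cnc3ccccn23)ccc1NC(=O)c1ccc([N+](=O)[O-])o1` is not yet measured. It differs from compound 2 by methyl in place of hydrogen on an aromatic carbon, on an aromatic carbon of a six-membered aromatic ring of carbon only, ortho to a large group and meta to a group of 9 heavy atoms.

The step that bears most directly is a 1.1-fold higher number from compound 2 to compound 3 (0.06 log units; within the scatter), the only measured addition of a small group to an aromatic carbon of the shared core, and it stays within the scatter. The steps of a 1.8-fold higher number from compound 1 to compound 2 (0.26 log units; within the scatter) and a 2.1-fold higher number from compound 1 to compound 3 (0.32 log units; beyond the scatter) remove a group of 9 heavy atoms and are of a different size of change; only the second is beyond the scatter, and modestly so. No step beyond the scatter is therefore expected in this assay.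

Compound 4 is estimated at 0.42 h in this assay, with a range of 0.24 h to 0.75 h. This estimate means an expected step of a 1.0-fold higher number from compound 2 to compound 4 (0.01 log units; within the scatter).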

Compound 4, half-life: 0.612 h
Compound 4: middle estimate off by 1.5-fold (0.16 log units), on the low side; low and high end bracket the measured number.
By their numbers in this assay, from the lowest: compounds 1, 2, 3 and 4 (each within the scatter of the next, the first and the last beyond it).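

In this assay, methyl on an aromatic carbon of a six-membered aromatic ring of carbon only, ortho to a large group and meta to a group of 9 heavy atoms, gives a 1.5-fold higher number from compound 2 to compound 4 (0.17 log units; within the scatter), so this ring, which carries no such substituent in compounds 1, 2 and 3, accepts a methyl without a step beyond the scatter. The other small addition to compound 2, methoxy on an aromatic carbon of the shared core, gives a 1.1-fold higher number from compound 2 to compound 3 (0.06 log units; within the scatter), so at both places a small group leaves the half-life of compound 2 within the scatter. Nothing measured on these compounds explains the number for compound 4.

From the compounds shown here alone, whether an ethyl, a methoxy, a fluorine or an amine at this same carbon would give a step beyond the scatter in this assay remains open. Also open, going by these compounds, is what the methyl does on other carbons of this ring, or when it is combined with the methoxy of compound 3 or the group of 9 heavy atoms of compound 1.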